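Extra hydroxy on a furan compound in the cytotoxicity assay

This account rests on a few compounds, and the source may have more. Where it says the series, first, only, none or still open, it means among the compounds named here.

Measured in an ADME assay on MDCK cells (Canis lupus familiaris) for cytotoxicity; on this read-out higher numbers stand for lower toxicity in this test and lower numbers for higher toxicity in this test:
Compound 1 `O=[N+]([O-])C1=CNc2nc(C(F)(F)F)nn2C1c1ccc(O)c(O)c1` gives 1210000 nM
Compound 2 `O=[N+]([O-])C1=CNc2nc(-c3ccco3)nn2C1c1ccc(O)c(O)c1` gives > 1200000 nM as a limit

Compound 2 stands only at a limit, > 1200000 nM, and not at a number. For the measured compounds named here, the single measured step, a step that the limit leaves unreadable from compound 1 to compound 2, offers no size to carry forward, and the limit of > 1200000 nM in this assay, at which 1 of the 2 values shown sits, is all the evidence there is on it. Compound 3 `O=[N+]([O-])C1=CNc2nc(-c3ccco3)nn2C1c1ccc(O)c(O)c1O` has hydroxy in place of hydrogen on an aromatic carbon. Going by the values given here, no measured step covers this change, so only a small fall is expected. The estimated change is an at least 1.2-fold lower number from compound 2 to compound 3 (0.07 log units; that floor lies within the scatter) in this read-out. Compound 3 is estimated at 1000000 nM, with an expected range from 400000 nM to 1300000 nM in this assay.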

Compound 3, half-maximal cytotoxic concentration: 317000 nM
The estimate for compound 3 lay 3.2-fold (0.50 log units) above the measured number, and the stated range ends above it.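

In this assay, hydroxy in place of hydrogen on this aromatic carbon, ortho to a hydroxy group, gives an at least 3.7-fold lower number from compound 2 to compound 3 (0.57 log units; beyond the scatter). Neither earlier compound showed that this position of the six-membered ring can move the read-out, and here the change goes toward higher toxicity in this test. The full size of the step stays open, since compound 2 is known only as a limit: the limit of > 1200000 nM in this assay, at which 1 of the 3 values shown sits.

From the compounds shown here alone, whether a methoxy group or an amine on this carbon would lower the number as well remains open. So does whether the same hydroxy would have a similar effect on the trifluoromethyl compound, compound 1.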